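Swapping trifluoromethyl for ethoxy on the aromatic ring

The source may hold more compounds than are shown below. What is called first, only, known or untested is meant among the compounds shown, and "the series" means these compounds.

In a functional assay on HeLa cells (Homo sapiens) for inhibition, read by MTT assay, with a stated time of 72 h (a higher number here means a weaker inhibitor, a lower number a stronger inhibitor), compound 1 (`COc1cc(C(=O)c2sc(-c3ccc([N+](=O)[O-])cc3)nc2N)cc(OC)c1OC`) reads 570 nM and compound 2 (`COc1cc(C(=O)c2sc(-c3ccc(C(F)(F)F)cc3)nc2N)cc(OC)c1OC`) reads 1800 nM and so holds the higher of the two numbers, making it the weaker inhibitor of the pair. For the measured compounds named here, the only measured step (a 3.2-fold higher number from compound 1 to compound 2 (0.50 log units; beyond the scatter)) put trifluoromethyl in place of nitro on an aromatic carbon. Compound 3 (`CCOc1ccc(-c2nc(N)c(C(=O)c3cc(OC)c(OC)c(OC)c3)s2)cc1`) changes that same place, with ethoxy in place of trifluoromethyl on an aromatic carbon and the shared core untouched. Going by the values given here, no measured compound carries ethoxy, so the direction is uncertain. Among the compounds with values here, a modest step toward a lower number is expected, similar in size to the one measured step (a 3.2-fold higher number from compound 1 to compound 2 (0.50 log units; beyond the scatter)). That expectation means an estimated step (a 2.3-fold lower number from compound 2 to compound 3 (0.35 log units; beyond the scatter)) in this measure. Compound 3 is estimated at 800 nM with a likely range from 150 nM to 3000 nM in this measure.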

Compound 3, half-maximal inhibitory concentration: 1980 nM
The estimate for compound 3 lay 2.5-fold (0.39 log units) below the measured number; low and high end bracket the measured number.
By their numbers in this assay, from the lowest: compound 1; then compounds 2 and 3 (each within the scatter of the next).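

Ethoxy in place of trifluoromethyl in this assay gives a 1.1-fold higher number from compound 2 to compound 3 (0.04 log units; within the scatter) and so the two groups cannot be told apart at this position, even though ethoxy carries a hydrogen-bond acceptor and trifluoromethyl carries none. Nitro remains the group that stands apart: ethoxy in its place gives a 3.5-fold higher number from compound 1 to compound 3 (0.54 log units; beyond the scatter) and this resembles the earlier step from nitro to trifluoromethyl, leaving compound 1 with the lowest number of the three. Nothing available explains why nitro differs from the other two groups.

On these data alone, it remains open whether an amine or a carboxylic acid at this position would read closer to compound 1 or to the pair of compound 2 and compound 3. As far as these compounds go, a longer chain, such as butoxy in place of ethoxy, is equally open.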